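The compounds below may be only part of what the source reports. "The series", "measured", "known", "first", "only" and "open" are said of these compounds alone.

Working notes on the series. The shared core of compound 1 `COc1cccc(OC)c1C(=O)Nc1ccc(C(=O)/C=C/c2nc(C)c(C)nc2C)cc1` carries an amide whose aryl is the point of variation. Among the measured compounds shown here, in a functional assay on A549 cells (Homo sapiens) for antiproliferative activity, read by CCK-8 assay, with a stated time of 72 h (on this read-out higher numbers stand for weaker inhibition and lower numbers for stronger inhibition), compound 1 gives 8470 nM, the second highest of the three numbers so far. Compound 2 `Cc1nc(C)c(/C=C/C(=O)c2ccc(NC(=O)c3ccc(F)cc3)cc2)nc1C` gives 4480 nM, and compound 3 `Cc1ccc(C(=O)Nc2ccc(C(=O)/C=C/c3nc(C)c(C)nc3C)cc2)cc1` gives 9990 nM. The step of a 1.9-fold lower number from compound 1 to compound 2 (0.28 log units; within the scatter) and the step of a 1.2-fold higher number from compound 1 to compound 3 (0.07 log units; within the scatter) both stay inside the scatter, while the step of a 2.2-fold higher number from compound 2 to compound 3 (0.35 log units; beyond the scatter) just passes it. Compound 4 `COc1cc(OC)cc(C(=O)Nc2ccc(C(=O)/C=C/c3nc(C)c(C)nc3C)cc2)c1` is not yet measured; it differs from compound 1 in that (3,5-dimethoxyphenyl in place of 2,6-dimethoxyphenyl on a carbonyl carbon). For the measured compounds named here, both measured steps from compound 1 alter this same aryl and both were small, which is what bears on the present change; no measured pair tests moving the two methoxy groups on the ring itself. The expectation is therefore no step beyond the scatter in either direction. In this assay compound 4 is estimated at 8000 nM, with a range from 3500 nM to 18000 nM. The expected step is a 1.1-fold lower number from compound 1 to compound 4 (0.02 log units; within the scatter).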

Compound 4, half-maximal inhibitory concentration: 10200 nM
Estimate against measurement, compound 4: 1.3-fold (0.11 log units) below; the measured number falls inside the stated range.
By their numbers in this assay, from the lowest: compounds 2, 1, 3 and 4 (each within the scatter of the next, the first and the last beyond it).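

Moving the two methoxy groups around the ring, with the same atoms joined differently, is now tested directly in this assay and gives a 1.2-fold higher number from compound 1 to compound 4 (0.08 log units; within the scatter) with no separation from the scatter. Against the 4-methylphenyl amide the result is a 1.0-fold higher number from compound 3 to compound 4 (0.01 log units; within the scatter) and also lies within the scatter, while against the 4-fluorophenyl amide it is a 2.3-fold higher number from compound 2 to compound 4 (0.36 log units; beyond the scatter) and only modestly beyond it. Nothing available explains these numbers.

Still open, as far as these compounds go, is whether an aryl bearing an amine or a carboxylic acid on this carbonyl carbon would move the number further than these modest differences. The rest of the shared core is the same in all four compounds, so the effect of changes there cannot be judged from this set.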